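Adding a methyl group to the phenyl amide compound 2

The source may hold more compounds than are shown below. What is called first, only, known or untested is meant among the compounds shown, and "the series" means these compounds.

Compound 1 `O=C(CCCCC(S)CCS)NO`: 47.5%
Compound 2 `O=C(CCCCC(S)CCS)Nc1ccccc1`: 7.67%
Compound 3 `O=C(CCCCC(S)CCS)Nc1ccc(F)cc1`: 11.7%

All three compounds were tested in a functional assay on Bel-7402 cells (Homo sapiens) for inhibition, read by MTT assay, with a stated time of 24 h, tested at 100 ug/mL; a lower number here means less inhibition of growth, a higher number more inhibition of growth at the concentration tested. Compound 2 gives 7.67%, at the low end of these numbers and within the usual scatter of compound 3 at 11.7%. Placing phenyl instead of hydroxy on the amide-type nitrogen produced a large drop, a number 39.8 percentage points lower from compound 1 to compound 2 (beyond the scatter).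

The next compound to be measured is compound 4 `Cc1cccc(NC(=O)CCCCC(S)CCS)c1`. Its structure differs from that of compound 2 by methyl in place of hydrogen on an aromatic carbon, meta to a large group.

The large drop involved the amide-type nitrogen, not the aromatic ring, so it offers little guidance here. The closer precedent is fluoro in place of hydrogen on an aromatic carbon, a number 4 percentage points higher from compound 2 to compound 3 (within the scatter), a change within the scatter. Within the data shown here, this is only one example, and it involves a different group, so the forecast remains tentative. The expected result is a number 1.3 percentage points higher from compound 2 to compound 4 (within the scatter), which would be no real change beyond the scatter. For compound 4, the estimated value is 9%, with an expected range from 2% to 18%.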

Compound 4, percent growth inhibition at one concentration: 7.08%
The estimate for compound 4 lay 1.9 percentage points above the measured number; the range from low to high includes it.
By their numbers in this assay, from the lowest: compounds 4, 2 and 3 (each within the scatter of the next); then compound 1.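

In this assay, among these compounds, the new change, methyl in place of hydrogen on an aromatic carbon, meta to a large group, gives a number 0.6 percentage points lower from compound 2 to compound 4 (within the scatter) and is the first carbon group placed on the phenyl ring of this series. Alongside the earlier ring change, which gave a number 4 percentage points higher from compound 2 to compound 3 (within the scatter), it makes two small substitutions on the ring that leave the number within the scatter, while the change on the amide-type nitrogen gave a number 39.8 percentage points lower from compound 1 to compound 2 (beyond the scatter), so among these four compounds only the nitrogen change shows an effect beyond the scatter. No measurement here explains why this methyl leaves the number where it stands.

The compounds shown leave open whether a different group on this ring, such as an amine, a carboxylic acid or a longer chain, would move the number beyond the scatter. They also leave open whether such a group would bring a phenyl amide anywhere near compound 1 at 47.5%. Nor do they show whether the same methyl would behave alike on another carbon of the ring.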